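Working notes: 4-methoxyphenyl to cyclopentyl in the series

The compounds below may be only part of what the source reports. "The series", "measured", "known", "first", "only" and "open" are said of these compounds alone.

Measured so far in a functional assay on HeLa cells (Homo sapiens) for cytotoxicity, read by WST assay, with a stated time of 48 h; on this read-out lower numbers stand for stronger inhibition and higher numbers for weaker inhibition:
- compound 1 `O[C@@H](c1ccccc1)[C@H]1CO[C@H](c2ccccc2)[C@@H](C/C=C/c2ccccc2)C1`: 6060 nM
- compound 2 `Oc1ccc(/C=C/C[C@H]2C[C@@H]([C@@H](O)c3ccccc3)CO[C@@H]2c2ccccc2)cc1`: 14400 nM
- compound 3 `COc1ccc(/C=C/C[C@H]2C[C@@H]([C@@H](O)c3ccccc3)CO[C@@H]2c2ccccc2)cc1`: 8300 nM

Compound 3 stands within the scatter of both other numbers. The gaps are a 1.4-fold higher number from compound 1 to compound 3 (0.14 log units; within the scatter) and a 1.7-fold lower number from compound 2 to compound 3 (0.24 log units; within the scatter).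

The next structure is compound 4 `O[C@@H](c1ccccc1)[C@H]1CO[C@H](c2ccccc2)[C@@H](C/C=C/C2CCCC2)C1`. It carries cyclopentyl in place of 4-methoxyphenyl on a double-bonded chain carbon bound to a double-bonded chain carbon.

The measured steps bear on this only indirectly, since each of them alters a substituent on the aromatic ring and none removes the ring. Hydroxy in place of hydrogen gave a 2.4-fold higher number from compound 1 to compound 2 (0.38 log units; beyond the scatter), the only step beyond the scatter, and it is modest. Methoxy in place of hydrogen gave a 1.4-fold higher number from compound 1 to compound 3 (0.14 log units; within the scatter), and methyl in place of hydrogen on the oxygen gave a 1.7-fold lower number from compound 2 to compound 3 (0.24 log units; within the scatter). On these data alone, replacing the whole aromatic group is untested, so the range has to stay wide. In this assay no step beyond the scatter is expected. The expected change is a 1.0-fold lower number from compound 3 to compound 4 (0.02 log units; within the scatter). For compound 4 the estimated value is 8000 nM, with an expected range of 3000 nM to 20000 nM.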

Compound 4, half-maximal inhibitory concentration: 9330 nM
Compound 4: the middle estimate sits 1.2-fold (0.07 log units) below what was measured; measured number inside the range.
By their numbers in this assay, from the lowest: compounds 1, 3, 4 and 2 (each within the scatter of the next, the first and the last beyond it).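

In this assay, among these compounds, the earlier steps only changed a substituent on the aromatic ring, whereas compound 4 removes that ring altogether at this place, on a double-bonded chain carbon bound to a double-bonded chain carbon. Cyclopentyl, a five-membered non-aromatic ring of carbon only, stands within the scatter of all three aromatic groups: against 4-methoxyphenyl (a 1.1-fold higher number from compound 3 to compound 4 (0.05 log units; within the scatter)), 4-hydroxyphenyl (a 1.5-fold lower number from compound 2 to compound 4 (0.19 log units; within the scatter)) and phenyl (a 1.5-fold higher number from compound 1 to compound 4 (0.19 log units; within the scatter)), so among these compounds an aromatic ring at this place is not needed to keep the read-out in the same range. No available evidence explains this result.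

The compounds shown leave open whether this tolerance extends to groups of another kind at the same place, such as a piperidine ring, a carboxylic acid or a longer alkyl chain. They also leave open whether any change at this place can move the number beyond the scatter in either direction, and whether the double bond of the 2-cyclopentylethenyl group can give way to a saturated chain.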